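From Chlorophenyl to Benzyl on the Shared Core

A few compounds are considered here, and "the series" means these few. Any claim that something is new, unique, unknown or untested is made for them only; others in the source may bear on it.

Compound 1 `CCOC(=O)c1cnc(-c2ccc(OC)cc2)nc1NN1C(=O)C=C(C)C1=O` and compound 2 `CCOC(=O)c1cnc(-c2ccc(Cl)cc2)nc1NN1C(=O)C=C(C)C1=O` share one core and differ only in the group on the pendant aromatic ring. In a functional assay on Jurkat cells for inhibition of nuclear factor NF-kappa-B complex (Homo sapiens) (a lower number here means a stronger inhibitor, a higher number a weaker inhibitor), compound 1 gives 900 nM, and compound 2 gives 300 nM. Among the compounds with values here, the single measured step, a 3.0-fold lower number from compound 1 to compound 2 (0.48 log units; beyond the scatter), leaves compound 2 with the lowest of the two numbers. Compound 3 `CCOC(=O)c1cnc(Cc2ccccc2)nc1NN1C(=O)C=C(C)C1=O` brings (benzyl in place of 4-chlorophenyl on an aromatic carbon). Within the data shown here, no measured step bears directly on this change: the step from compound 1 to compound 2 concerns a substituent on the same ring rather than the exchange of the whole 4-chlorophenyl for benzyl, so it only shows the scale over which this assay has moved so far. Among the measured compounds shown here, with no comparable precedent, any expectation for compound 3 must stay wide. The estimate for compound 3 is 900 nM, with an expected range from 200 nM to 4000 nM. This estimate means an expected step of a 3.0-fold higher number from compound 2 to compound 3 (0.48 log units; beyond the scatter).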

Compound 3, half-maximal inhibitory concentration: 7000 nM
The estimate for compound 3 lay 7.8-fold (0.89 log units) below the measured number; measured number above the stated range.
By their numbers in this assay, from the lowest: compound 2; then compound 1; then compound 3.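

In this assay this position, on the aromatic carbon between two ring nitrogen atoms, proves far more sensitive to replacing the whole group than to changing the substituent on the ring: the benzyl change gives a 23-fold higher number from compound 2 to compound 3 (1.37 log units; beyond the scatter) and, from the other aryl compound, a 7.8-fold higher number from compound 1 to compound 3 (0.89 log units; beyond the scatter). Both steps go the same way and lie beyond the scatter, so benzyl is weaker here than either 4-chlorophenyl or 4-methoxyphenyl, even though benzyl and 4-chlorophenyl have the same heavy-atom count and one carbon aromatic ring each. Nothing available explains this loss.

The change removes the chloro and inserts a methylene at once, so the compounds shown do not separate the two. A plain unsubstituted phenyl or a 4-chlorobenzyl group would be needed to tell which part carries the loss.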